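This account rests on a few compounds, and the source may have more. Where it says the series, first, only, none or still open, it means among the compounds named here.

Compound 1 `COc1ccc2c(=O)c(/C=C/C(=O)Nc3ccccc3Cl)coc2c1` gives 22400 nM in a functional assay on HeLa cells (Homo sapiens) for inhibition, read by MTT assay, with a stated time of 48 h; on this read-out lower numbers stand for stronger inhibition and higher numbers for weaker inhibition.
Compound 2 `COc1ccc2c(=O)c(/C=C/C(=O)Nc3ccccc3OC)coc2c1` gives > 100000 nM in this assay, which is a limit and not a number.

Compound 2 therefore stands at the limit of > 100000 nM in this assay, at which 1 of the 2 values shown sits, so only a range is known for it. Compound 3 `COc1ccc2c(=O)c(/C=C/C(=O)Nc3ccc(F)cc3)coc2c1` differs from compound 2 by 4-fluorophenyl in place of 2-methoxyphenyl on an amide-type nitrogen. Among the measured compounds shown here, only one measured step bears on this change: an at least 4.4-fold higher number from compound 1 to compound 2 (0.64 log units; beyond the scatter) when methoxy entered in place of chloro. Because an at least 4.4-fold higher number from compound 1 to compound 2 (0.64 log units; beyond the scatter) went toward weaker inhibition, and compound 3 removes that methoxy, a step back toward stronger inhibition is expected, roughly an at least 2.5-fold lower number from compound 2 to compound 3 (0.39 log units; beyond the scatter). Compound 3 is estimated at 40000 nM, with a range from 15000 nM to 150000 nM.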

Compound 3, half-maximal inhibitory concentration: 9680 nM
Estimate against measurement, compound 3: 4.1-fold (0.62 log units) above; the whole stated range lies above it.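

Replacing the group on the amide-type nitrogen does more than undo the loss seen with methoxy: 4-fluorophenyl gives an at least 10-fold lower number from compound 2 to compound 3 (1.01 log units; beyond the scatter). It also improves on the chloro compound, with a 2.3-fold lower number from compound 1 to compound 3 (0.36 log units; beyond the scatter). The first of these steps has only a lower bound on its size, as compound 2 is known only as a limit: the limit of > 100000 nM in this assay, at which 1 of the 3 values shown sits.

Still open, on these data alone, is whether the gain comes from fluorine itself or from where it sits on the phenyl ring. As far as these compounds go, how an amine or a carboxylic acid on that ring would read also remains unknown.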